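This account rests on a few compounds, and the source may have more. Where it says the series, first, only, none or still open, it means among the compounds named here.

Measured compounds:
compound 1 `Clc1ccc(Nc2nnc(Cc3ccccc3)o2)cc1` — 31000 nM
compound 2 `Clc1ccc(Cc2nnc(Nc3ccc(Cl)cc3)o2)cc1` — > 100000 nM

Both compounds were tested in a functional assay on MT2 cells (Homo sapiens) for cytotoxicity, read by MTT assay; on this read-out lower numbers stand for higher toxicity in this test and higher numbers for lower toxicity in this test. Compound 1 gives a measured number there. For compound 2 the value > 100000 nM is not a number but a limit of the test; compound 2 therefore sits at the limit of > 100000 nM in this assay, at which 1 of the 2 values shown sits, the upper edge of what this assay can report. Among the measured compounds shown here, the only step seen so far, an at least 3.2-fold higher number from compound 1 to compound 2 (0.50 log units; beyond the scatter), shows that adding chlorine to the benzyl ring of compound 1 moved the number upward, to the limit, that is toward lower toxicity.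

Compound 3 `Clc1ccc(Nc2nnc(Cc3cccc(Cl)c3)o2)cc1` differs from compound 2 by 3-chlorophenyl in place of 4-chlorophenyl on a saturated chain carbon bound to an aromatic carbon. For the measured compounds named here, no measured step shifts a chlorine between positions on that ring, so the one step available, from compound 1 to compound 2, bears only loosely: it tells that a chlorine on this ring is compatible with a value at or beyond the limit, but not whether its position matters. The expected step of a number no higher from compound 2 to compound 3 (the limit leaves the size open) is therefore none beyond the scatter. Compound 3 is estimated at 100000 nM in this assay, within a range from 40000 nM to 250000 nM.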

Compound 3, half-maximal cytotoxic concentration: 32000 nM
Beside the measured number, compound 3's estimate is 3.1-fold (0.49 log units) above it, outside the stated range (below it).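

Replacing 4-chlorophenyl with 3-chlorophenyl on the saturated chain carbon gives an at least 3.1-fold lower number from compound 2 to compound 3 (0.49 log units; beyond the scatter) in this assay, so the position of the chlorine on this ring matters, even though both compounds contain the same atoms. The value of compound 2 is a limit and not a number, so the full size of this step cannot be read: the limit of > 100000 nM in this assay, at which 1 of the 3 values shown sits.

The chlorine of the 3-chlorophenyl group, by contrast, makes no readable difference against the ring without chlorine, a 1.0-fold higher number from compound 1 to compound 3 (0.01 log units; within the scatter), while the 4-chlorophenyl group gave an at least 3.2-fold higher number from compound 1 to compound 2 (0.50 log units; beyond the scatter), which ties the upward shift to that one placement and not to any chlorine on this ring.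

The compounds shown leave open whether a group other than chlorine, such as methoxy or a carboxylic acid, would show the same dependence on position, and whether the pattern would survive a longer chain in place of the present link to the core. They also give no explanation of why the two chlorine placements differ in this assay, and the true value of compound 2 remains unknown.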